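A few compounds are considered here, and "the series" means these few. Any claim that something is new, unique, unknown or untested is made for them only; others in the source may bear on it.

Of the compounds shown here, two with the same sulfonamide-bearing aryl end have been tested so far. Compound 1 `COc1ccccc1Nc1ncnc2cc(OC)c(OCCCCC(=O)Nc3ccc(S(N)(=O)=O)cc3)cc12` gives 8030 nM in a functional assay on NCI-H1975 cells (Homo sapiens) for antiproliferative activity, read by MTT assay, with a stated time of 72 h; a lower number here means a stronger inhibitor, a higher number a weaker inhibitor. Compound 2 `NS(=O)(=O)c1ccc(NC(=S)Nc2ccc3ncnc(Nc4ccc(F)c(Cl)c4)c3c2)cc1` gives 15800 nM in this assay, the higher of the two numbers; the gap between compound 1 and compound 2 lies within the scatter of repeated runs, so neither can be called the weaker of the pair, and the two differ in several places at once, so nothing is shown about any single change between them.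

Compound 3 `NS(=O)(=O)c1ccc(NC(=S)Nc2ccc3ncnc(Nc4cccc(C(F)(F)F)c4)c3c2)cc1` keeps the core of compound 2 and changes only the group on the nitrogen on an aromatic ring: 3-(trifluoromethyl)phenyl in place of 3-chloro-4-fluorophenyl on a nitrogen on an aromatic ring. Among the compounds with values here, no measured pair shows what this exchange does on its own, and the two values seen so far leave the effect open.

With nothing in the measured compounds pointing in either direction, the step of a 1.1-fold higher number from compound 2 to compound 3 (0.06 log units; within the scatter) is expected to stay within the scatter. Compound 3 is therefore estimated at 18000 nM, with a likely range from 6000 nM to 55000 nM.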

Compound 3, half-maximal inhibitory concentration: 7590 nM
The estimate for compound 3 lay 2.4-fold (0.38 log units) above the measured number, within the range that was stated.
By their numbers in this assay, from the lowest: compounds 3, 1 and 2 (each within the scatter of the next, the first and the last beyond it).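

In this assay, within the data shown here, placing 3-(trifluoromethyl)phenyl in place of 3-chloro-4-fluorophenyl on a nitrogen on an aromatic ring gives a 2.1-fold lower number from compound 2 to compound 3 (0.32 log units; beyond the scatter), the first change at a single place that can be read. It shows that the group at this place can move the number beyond the usual scatter, though the step is modest and only just clears it. No measurement at hand bears on the reason for this step, so it stands as an observed difference only.

The compounds shown leave open whether the lower number comes from the trifluoromethyl group itself or from the loss of the chlorine and fluorine, and whether the same exchange would give a step of similar size on the core of compound 1. Also open, from the compounds shown here alone, is what an unsubstituted phenyl, a 3-ethynylphenyl or a phenyl carrying an amine would do on this nitrogen, and how a urea in place of the thiourea or a carboxylic acid in place of the sulfonamide would change the number.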